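Replacing the hydroxycyclohexylmethyl arm of a weak kinase inhibitor

The source may report more compounds than this note shows. Statements on the series, on what has been measured and on what is new or still open speak of the compounds shown alone.

The account concerns two measured compounds and one that awaits a number. In an assay on isolated protein for inhibition of protein kinase C delta type (Homo sapiens), read by TR-FRET, with a stated time of 2 h (on this read-out lower numbers stand for stronger inhibition and higher numbers for weaker inhibition), compound 1 `N#Cc1cnc(NCc2cnccc2C(F)(F)F)cc1NC[C@H]1CC[C@H](O)CC1` gives 2000 nM, the higher of the two values recorded. Going by the values given here, compound 2 `CC(C)(F)c1ncncc1CNc1cc(N[C@H]2CC[C@@H](O)CC2)c(C#N)cn1` gives 32 nM in this assay, a gap from compound 1 that lies well beyond the usual scatter; no single-point step between the two is recorded, so only the two values themselves can be compared.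

Compound 3 `CC1(C)[C@@H](Nc2cc(NCc3cnccc3C(F)(F)F)ncc2C#N)C[C@@H]1C(N)=O` differs from compound 1 in one place: 3-carbamoyl-2,2-dimethylcyclobutyl in place of (4-hydroxycyclohexyl)methyl on a nitrogen on an aromatic ring. The change removes the (4-hydroxycyclohexyl)methyl group, with its six-membered ring and one hydroxyl donor, and installs the 3-carbamoyl-2,2-dimethylcyclobutyl group, with its four-membered ring and one amide donor and acceptor, on the same nitrogen on the aromatic ring.

Among the compounds with values here, no measured pair describes this exchange, so the step can only be guessed. Since compound 1 sits at the high end of the numbers seen, a move toward stronger inhibition is expected, of moderate size, in the step of a 6.7-fold lower number from compound 1 to compound 3 (0.82 log units; beyond the scatter). Compound 3 is therefore expected to give about 300 nM in this assay, plausibly between 50 nM and 1500 nM.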

Compound 3, half-maximal inhibitory concentration: > 10000 nM
Compound 3: only a limit was reported (the forecaster's own chance of this, stated with the estimate: 5%); at least 33-fold (1.52 log units) between middle value and limit.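

In this assay compound 3 returns only a limit and not a number: the limit of > 10000 nM in this assay, at which 1 of the 3 values shown sits. Placing 3-carbamoyl-2,2-dimethylcyclobutyl in place of (4-hydroxycyclohexyl)methyl on this nitrogen gives an at least 5.0-fold higher number from compound 1 to compound 3 (0.69 log units; beyond the scatter), so this position, already held by a weak group in compound 1, still has room to lose inhibition, and the new group does not recover any. The earlier compounds shown here could not show this, and it also shows that keeping the same count of hydrogen-bond donors and acceptors on the two groups does not keep the inhibition at this position.

The four-membered ring, the two methyl groups, the carbamoyl group and the loss of the methylene link all change together in this one step, so the compounds shown do not say which of them accounts for the result. Going by these compounds, it remains open how a plain cyclobutyl, a 3-hydroxycyclobutyl or a cyclohexyl carrying a carbamoyl group would read on the same nitrogen of the core of compound 1.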